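The source may hold more compounds than are shown below. What is called first, only, known or untested is meant among the compounds shown, and "the series" means these compounds.

Values in an ADME assay on Vero 76 cells (Chlorocebus sabaeus) for cytotoxicity, read by crystal violet staining, with a stated time of 96 h; on this read-out lower numbers stand for higher toxicity in this test and higher numbers for lower toxicity in this test:

Compound 1 `O=C(NC(=S)Nc1cccc(C(F)(F)F)c1)c1ccccc1`: > 100000 nM
Compound 2 `COc1cccc(NC(=S)Nc2cccc(C(F)(F)F)c2)c1`: 20000 nM
Compound 3 `Cc1ccc(NC(=S)Nc2cccc(C(F)(F)F)c2)cc1Cl`: 20000 nM

Compound 1 sits at the limit of > 100000 nM in this assay, at which 1 of the 3 values shown sits, and this reading is a limit of the assay and not a number. Compound 2 gives 20000 nM, and compound 3 gives 20000 nM, so these two show the same figure. The account now turns to compound 4 `O=C(NC(=S)Nc1cccc(C(F)(F)F)c1)[C@H]1C[C@@H]2CC[C@H]1C2`, which keeps the core of compound 1 and changes one group on a carbonyl carbon: a group of 7 heavy atoms (7 carbon; 2 five-membered non-aromatic rings of carbon only) in place of a group of 6 heavy atoms (6 carbon; one six-membered aromatic ring of carbon only), on a carbonyl carbon. The phenyl leaves, and a group with 2 five-membered non-aromatic rings of carbon only enters.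

Among the compounds with values here, no measured pair in this assay shows what such an exchange does, so any forecast here is loose. The expectation is for little or no change beyond the usual scatter, with any clear shift going toward lower numbers. That lean rests on compound 1 itself, whose reading of > 100000 nM is a limit. The expected change is an at least 1.2-fold lower number from compound 1 to compound 4 (0.09 log units; that floor lies within the scatter). For compound 4 the estimated value is 80000 nM, with an expected range from 30000 nM to 100000 nM, and the assay may well report only a limit again.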

Compound 4, half-maximal cytotoxic concentration: 20000 nM
The estimate for compound 4 lay 4.0-fold (0.60 log units) above the measured number, and the stated range ends above it.
By their numbers in this assay, from the lowest: compounds 2, 3 and 4 (each within the scatter of the next). At a limit, above all of these: compound 1.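

In this assay compound 1 gives > 100000 nM, which is a limit of the assay and not a number. Within the data shown here, replacing the phenyl on the carbonyl carbon with the group of 2 five-membered non-aromatic rings of carbon only gives an at least 5.0-fold lower number from compound 1 to compound 4 (0.69 log units; beyond the scatter), the first step that can be read, and it shows that a change at this one place, with the rest of the core of compound 1 kept, can move the read-out toward higher toxicity in this test by more than the scatter. How large the step really is stays unknown because it starts from a limit: the limit of > 100000 nM in this assay, at which 1 of the 4 values shown sits.

The compounds shown leave open whether any non-aromatic carbon group on this carbonyl carbon, such as a cyclohexyl ring or a straight butyl chain, gives a number like that of compound 4, or whether this particular group with its 3 defined stereocentres is needed. They also leave open what a group carrying an amine or a carboxylic acid does at this place, and whether the mirror-image form of the entering group reads the same.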